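A few compounds are considered here, and "the series" means these few. Any claim that something is new, unique, unknown or untested is made for them only; others in the source may bear on it.

Three members of the series are measured in a functional assay on NCI-H23 cells (Homo sapiens) for cytotoxicity, read by sulforhodamine B assay, tested at 10 uM; a higher number here means more inhibition at the concentration tested (going by the name of the read-out), a lower number less inhibition. Compound 1 `CCCCCCCCc1cc(-c2cn([C@H]3C[C@H](O)[C@@H](CO)O3)c(=O)[nH]c2=O)on1` gives 120%, compound 3 `CC(C)(C)c1ccc(-c2cc(-c3cn([C@H]4C[C@H](O)[C@@H](CO)O4)c(=O)[nH]c3=O)on2)cc1` gives 98.9%, and compound 2 `CCCc1cc(-c2cn([C@H]3C[C@H](OC(C)=O)[C@@H](COC(C)=O)O3)c(=O)[nH]c2=O)on1` gives 96.9%. Compound 2 thus holds the lowest of the three readings, but its gap to compound 3 lies within the scatter; only compound 1 sits clearly higher. Compound 4 `CC(=O)OC[C@H]1O[C@@H](n2cc(-c3cc(-c4ccc(C(C)(C)C)cc4)no3)c(=O)[nH]c2=O)C[C@@H]1OC(C)=O` differs from compound 2 in one place: 4-(tert-butyl)phenyl in place of propyl on an aromatic carbon. The same entering group, 4-(tert-butyl)phenyl, appears once already in a measured step, a number 21.1 percentage points lower from compound 1 to compound 3 (beyond the scatter), there with octyl leaving rather than propyl. That step began from a very high reading, and compound 3 lands near compound 2, so in this assay no step beyond the scatter is expected, a number 1.9 percentage points lower from compound 2 to compound 4 (within the scatter). Compound 4 is estimated at 95%, range 80% to 106%.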

Compound 4, a percentage reported as inhibition, at one concentration (the size of the read-out at that concentration, not a potency): 112%
Compound 4: the middle estimate sits 17 percentage points below what was measured; the whole stated range lies below it.
By their numbers in this assay, from the lowest: compounds 2 and 3 (each within the scatter of the next); then compounds 4 and 1 (each within the scatter of the next).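

At this position on the five-membered aromatic ring, 4-(tert-butyl)phenyl in place of propyl gives in this assay a number 15.1 percentage points higher from compound 2 to compound 4 (beyond the scatter), so the entering group does not lower the reading in every setting. With octyl leaving, the same group gave a number 21.1 percentage points lower from compound 1 to compound 3 (beyond the scatter), so its direction differs between the two steps, which also differ in the leaving chain and in the acetate esters carried by compound 2 and compound 4. No measurement available here explains this difference.

Whether the direction follows the leaving chain or the acetate esters stays open, since octyl is shown only without those esters. Going by these compounds, how an amine or a carboxylic acid at this position would read also remains open.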